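Replacing 4-bromobenzyl with 3-methylbenzyl at the assay limit

This account rests on a few compounds, and the source may have more. Where it says the series, first, only, none or still open, it means among the compounds named here.

Of the compounds shown here, three sharing one core have been measured in an ADME assay on NIH3T3 cells (Mus musculus) for cytotoxicity, with a stated time of 72 h; a lower number here means a stronger inhibitor, a higher number a weaker inhibitor. Compound 1 `OC[C@H]1O[C@@H](n2cnc3c(NCc4ccc(Cl)cc4)ncnc32)[C@H](O)[C@@H]1O` gives > 166000 nM, which is a limit. Compound 2 `OC[C@H]1O[C@@H](n2cnc3c(NCc4ccccc4Br)ncnc32)[C@H](O)[C@@H]1O` gives > 166000 nM, which is also a limit. Compound 3 `OC[C@H]1O[C@@H](n2cnc3c(NCc4ccc(Br)cc4)ncnc32)[C@H](O)[C@@H]1O` gives > 166000 nM, again a limit and not a number. Compound 3 therefore stands with the other two, and the limit of > 166000 nM in this assay, at which 3 of the 3 values shown sit, describes the whole set.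

The next compound, compound 4 `Cc1cccc(CNc2ncnc3c2ncn3[C@@H]2O[C@H](CO)[C@@H](O)[C@H]2O)c1`, carries 3-methylphenyl in place of 4-bromophenyl on a saturated chain carbon bound to a nitrogen on an aromatic ring.

Among the measured compounds shown here, three measured steps bear on this change, since each alters the same aromatic group: a step that the two limits leave unreadable from compound 1 to compound 2, a step that the two limits leave unreadable from compound 1 to compound 3 and a step that the two limits leave unreadable from compound 2 to compound 3. None of them has a readable size, so the data hold no measured effect of changing this group, and none of them involves a methyl group. With all three compounds at the same limit, compound 4 is expected to sit there too, and a report of only a limit is the likeliest result. The estimate means a step that the limit leaves unreadable from compound 3 to compound 4, which is expected to stay within the scatter, with no direction to be read. For compound 4 the expected value is 200000 nM, with an estimated range from 90000 nM to 400000 nM.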

Compound 4, half-maximal inhibitory concentration: > 166000 nM
Compound 4 ended at the assay's limit; the forecaster's own chance of this, stated with the estimate: 85%; the middle value does not contradict the limit.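

In this assay compound 4 gives > 166000 nM, which is a limit. The steps linking compound 4 to compound 1, compound 2 and compound 3 cannot be read, and all four share one result: the limit of > 166000 nM in this assay, at which 4 of the 4 values shown sit.

The compounds shown leave open whether changing this aromatic group has any effect on the result in this assay.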